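This account rests on a few compounds, and the source may have more. Where it says the series, first, only, none or still open, it means among the compounds named here.

Compound 1 `CCCCC(C)(O)CC(=O)O[C@H](CC=C(C)C)C1=CC(=O)c2c(O)ccc(O)c2C1=O` and compound 2 `CCCC(CC(=O)O[C@H](CC=C(C)C)C1=CC(=O)c2c(O)ccc(O)c2C1=O)OC(C)=O` share one core and differ in a single place. In a functional assay on DU-145 cells (Homo sapiens) for cytotoxicity, read by MTT assay (a higher number here means a weaker inhibitor, a lower number a stronger inhibitor), compound 1 gives 76500 nM, while compound 2 gives 55700 nM, so compound 2 stands alongside compound 1, the two numbers within the scatter of each other, as the step of a 1.4-fold lower number from compound 1 to compound 2 (0.14 log units; within the scatter) shows. Compound 3 `CCCCC(CC(=O)O[C@H](CC=C(C)C)C1=CC(=O)c2c(O)ccc(O)c2C1=O)OC(C)=O` differs from compound 2 by methyl in place of hydrogen on a saturated chain carbon, four bonds along the chain from an oxygen next to a carbonyl group. Going by the values given here, no measured step matches this change, and the only step known was within the scatter. The chemist therefore expects a step of a 1.1-fold lower number from compound 2 to compound 3 (0.05 log units; within the scatter) in this assay, nothing beyond the scatter. Compound 3 is estimated at 50000 nM, within 25000 nM to 100000 nM.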

Compound 3, half-maximal inhibitory concentration: 67700 nM
Compound 3: middle estimate off by 1.4-fold (0.13 log units), on the low side, within the range that was stated.
By their numbers in this assay, from the lowest: compounds 2, 3 and 1 (each within the scatter of the next).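

In this assay, methyl in place of hydrogen at this place on the chain gives a 1.2-fold higher number from compound 2 to compound 3 (0.08 log units; within the scatter), so the butyl-to-pentyl difference does not separate the two compounds. The second new step, a 1.1-fold lower number from compound 1 to compound 3 (0.05 log units; within the scatter), shows that 1-acetoxypentyl in place of 1-hydroxy-1-methylpentyl also stays within the scatter, so all three compounds now lie within the scatter of one another. Nothing available accounts for these results. On these data alone, whether an amine, a carboxylic acid or a much longer chain here would give a step beyond the scatter remains open.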